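A few compounds are considered here, and "the series" means these few. Any claim that something is new, unique, unknown or untested is made for them only; others in the source may bear on it.

Three compounds have been measured in an ADME assay on HepG2 cells (Homo sapiens) for cytotoxicity, read by luminescence, CellTiter-Glo and ATP content, with a stated time of 72 h; a lower number here means that less compound is needed, a higher number that more compound is needed for the effect:

compound 1, `COc1cccc(CNCCCNc2ccnc3cc(Cc4cccc(C(F)(F)F)c4)ccc23)c1O`, with 1720 nM
compound 2, `COc1cccc(CNCCCNc2ccnc3cc(Cc4ccc(C#N)cc4)ccc23)c1O`, with 7150 nM
compound 3, `COc1cccc(CNCCCNc2ccnc3cc(-c4ccccc4)ccc23)c1O`, with 3210 nM

Compound 3 stands second highest of the three numbers. Its nearest neighbour is compound 1, and the step of a 1.9-fold higher number from compound 1 to compound 3 (0.27 log units; within the scatter) lies within the scatter; its furthest is compound 2, and the step of a 2.2-fold lower number from compound 2 to compound 3 (0.35 log units; beyond the scatter) is modest but beyond the scatter. All three compounds share the same core and differ only in the group carried on one aromatic carbon of that core.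

Compound 4, `COc1cccc(CNCCCNc2ccnc3cc(Oc4ccc(Cl)cc4)ccc23)c1O`, alters that same position once more: 4-chlorophenoxy in place of phenyl on an aromatic carbon. The two steps that bear on it are those leading into compound 3, a 1.9-fold higher number from compound 1 to compound 3 (0.27 log units; within the scatter) and a 2.2-fold lower number from compound 2 to compound 3 (0.35 log units; beyond the scatter), since each also exchanges the group on this aromatic carbon. Both are small, one within the scatter and one only modestly beyond it, and they point in opposite directions. The number for compound 4 is therefore expected to sit close to that of compound 3, with a step of a 1.2-fold lower number from compound 3 to compound 4 (0.08 log units; within the scatter) that need not exceed the scatter in either direction. Compound 4 is estimated at 2700 nM in this assay, with a range from 1100 nM to 7000 nM.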

Compound 4, half-maximal effective concentration: 5700 nM
Compound 4: middle estimate off by 2.1-fold (0.32 log units), on the low side, within the range that was stated.
By their numbers in this assay, from the lowest: compounds 1, 3, 4 and 2 (each within the scatter of the next, the first and the last beyond it).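

Placing 4-chlorophenoxy on this aromatic carbon brings in a group with an oxygen link and a chlorine, yet in this assay the exchange for phenyl gives only a 1.8-fold higher number from compound 3 to compound 4 (0.25 log units; within the scatter), and the exchange for 4-cyanobenzyl gives only a 1.3-fold lower number from compound 2 to compound 4 (0.10 log units; within the scatter), so compound 4 cannot be told apart from either compound 3 or compound 2. Only the exchange for 3-(trifluoromethyl)benzyl reaches past the scatter, with a 3.3-fold higher number from compound 1 to compound 4 (0.52 log units; beyond the scatter), and that step remains modest. Compound 4 thus stays inside the spread already set by the two benzyl compounds, a 4.2-fold higher number from compound 1 to compound 2 (0.62 log units; beyond the scatter), which shows that this position accepts an oxygen-linked aryl group without a step larger than that spread.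

No measurement at hand accounts for any of these steps. Going by these compounds, compound 4 changes the link and the ring substituent together, so the separate contributions of the oxygen and the chlorine remain open, as a plain phenoxy group would be needed to divide them, and it is equally open whether an amine or a carboxylic acid on this aromatic carbon would move the number outside the present spread.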